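Swapping an ester for an amine-bearing ether on the core

This account rests on a few compounds, and the source may have more. Where it says the series, first, only, none or still open, it means among the compounds named here.

Measured compounds:
compound 1 `C[S+]([O-])c1c(F)c(N)c2c(=O)cc(-c3ccc(N)c(F)c3)oc2c1F` gives 2500 nM in a functional assay on MCF7 cells (Homo sapiens) for cytotoxicity, read by neutral red uptake, with a stated time of 3 days; a lower number here means a stronger inhibitor, a higher number a weaker inhibitor
compound 2 `CCC(=O)OCc1c(F)c(N)c2c(=O)cc(-c3ccc(N)c(F)c3)oc2c1F` gives 130 nM in this assay

For the measured compounds named here, compound 2 has the lower of the two numbers known so far; the nearest compound is compound 1, with a higher number, and the single step of a 19-fold lower number from compound 1 to compound 2 (1.28 log units; beyond the scatter) is large. Compound 3 `CN(C)CCCOCc1c(F)c(N)c2c(=O)cc(-c3ccc(N)c(F)c3)oc2c1F` is compound 2 with one change: 3-(dimethylamino)propyl in place of propanoyl on an oxygen on a saturated carbon. Going by the values given here, the only measured step, from compound 1 to compound 2, alters a different group at a different place, so it tells how much this part of the shared core can move the number but does not speak to this exact change. Among the compounds with values here, no measured pair shows an ester exchanged for an ether of this kind. Within the data shown here, with only one step to lean on, a step of modest size in either direction is the most reasonable expectation, and the estimate for compound 3 is set at 250 nM, within 60 nM to 1000 nM. That estimate corresponds to an expected step of a 1.9-fold higher number from compound 2 to compound 3 (0.28 log units; within the scatter), small next to the change seen earlier.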

Compound 3, half-maximal inhibitory concentration: > 10000 nM
Compound 3: a limit, no number (the forecaster's own chance of this, stated with the estimate: 5%); at least 40-fold (1.60 log units) between middle value and limit.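

In this assay compound 3 gives > 10000 nM, which is a limit of the assay and not a number. The earlier step changed the whole group on the aromatic carbon, whereas this one keeps the methylene and its oxygen in place and replaces only what sits on that oxygen, and exchanging propanoyl for 3-(dimethylamino)propyl gives an at least 76-fold higher number from compound 2 to compound 3 (1.88 log units; beyond the scatter), so this outer part of the side chain alone can decide much of the reading. Compound 1 also no longer marks the weak end of the series, since the new side chain gives an at least 4.0-fold higher number from compound 1 to compound 3 (0.60 log units; beyond the scatter).

The exchange removes a carbonyl and brings in a dimethylamino end in a single move, so the compounds shown cannot tell which of these carries the step. A plain propyl ether on the same oxygen, or a propanoyl chain ending in a dimethylamine, would separate the two, while a shorter amine chain would show whether the length of the chain matters.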